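The source may hold more compounds than are shown below. What is called first, only, known or untested is meant among the compounds shown, and "the series" means these compounds.

Compound 1 `O=C(/C=C/C(=O)N1C/C(=C\c2ccccc2)C(=O)/C(=C/c2ccccc2)C1)Nc1ccc([N+](=O)[O-])cc1` gives 31000 nM in a functional assay on Molt4/C8 cells (Homo sapiens) for cytotoxicity; on this read-out higher numbers stand for weaker inhibition and lower numbers for stronger inhibition. Compound 2 `Cc1cccc(C)c1NC(=O)/C=C/C(=O)N1C/C(=C\c2ccccc2)C(=O)/C(=C/c2ccccc2)C1` gives 6600 nM in this assay.

Going by the values given here, compound 2 holds the lower of the two numbers; the single step leading to it, a 4.7-fold lower number from compound 1 to compound 2 (0.67 log units; beyond the scatter), lies beyond the scatter. Compound 3 `CC(=O)c1ccc(NC(=O)/C=C/C(=O)N2C/C(=C\c3ccccc3)C(=O)/C(=C/c3ccccc3)C2)cc1` differs from compound 2 by 4-acetylphenyl in place of 2,6-dimethylphenyl on an amide-type nitrogen. Among the compounds with values here, no measured step covers this exact change. Within the data shown here, the only step in hand, a 4.7-fold lower number from compound 1 to compound 2 (0.67 log units; beyond the scatter), shows that 4-nitrophenyl in place of 2,6-dimethylphenyl at the same position goes with a higher number, so a partial move back toward compound 1 is expected, a 2.3-fold higher number from compound 2 to compound 3 (0.36 log units; beyond the scatter) in this assay. Compound 3 is estimated at 15000 nM, range 5000 nM to 45000 nM.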

Compound 3, half-maximal inhibitory concentration: 1400 nM
Beside the measured number, compound 3's estimate is 11-fold (1.03 log units) above it; the measured number lies below the stated range.
By their numbers in this assay, from the lowest: compound 3; then compound 2; then compound 1.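

On the amide-type nitrogen, the earlier pair did not mark the low end of the series: 4-acetylphenyl in place of 2,6-dimethylphenyl gives a 4.7-fold lower number from compound 2 to compound 3 (0.67 log units; beyond the scatter) in this assay, not a partial return toward 4-nitrophenyl. Acetyl in place of nitro on an aromatic carbon gives a 22-fold lower number from compound 1 to compound 3 (1.35 log units; beyond the scatter), the largest step in this set, from a change in one substituent. No measurement here gives a reason for this difference.

On these data alone, whether the carbonyl of the acetyl group carries the step remains open; a 4-aminophenyl, 4-carboxyphenyl or 4-propanoylphenyl group at this nitrogen would extend the comparison.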